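Cytotoxicity limits along an aryl amide series

A few compounds are considered here, and "the series" means these few. Any claim that something is new, unique, unknown or untested is made for them only; others in the source may bear on it.

Measured so far in an ADME assay on Karpas-1106P cells (Homo sapiens) for cytotoxicity; a lower number here means that less compound is needed, a higher number that more compound is needed for the effect:
Compound 1 `Cc1ccc(S(=O)(=O)N[C@@H](CC(=O)NC(C)(C)C)C(=O)NCCNC(=O)Nc2ccccc2)cc1` gives > 11100 nM; this value is a limit of the assay.
Compound 2 `Cc1ccc(S(=O)(=O)N[C@@H](CC(=O)NC(C)(C)C)C(=O)NCCNC(=O)c2ccccc2Cl)cc1` gives > 11100 nM; this value is also a limit of the assay.

Compound 2 thus stands where both measured values sit, at the limit of > 11100 nM in this assay, at which 2 of the 2 values shown sit. Compound 3 `Cc1ccc(S(=O)(=O)N[C@@H](CC(=O)NC(C)(C)C)C(=O)NCCNC(=O)c2cc(C)ccc2F)cc1` differs from compound 2 by 2-fluoro-5-methylphenyl in place of 2-chlorophenyl on a carbonyl carbon. Among the compounds with values here, the only measured step, a step that the two limits leave unreadable from compound 1 to compound 2, is unreadable because both of its ends are limits, so no size or direction can be taken from it. With nothing to suggest a shift beyond the scatter, compound 3 is expected to sit at the same limit, a step of a number no higher from compound 2 to compound 3 (the limit leaves the size open), giving an estimated 11100 nM within 5000 nM to 30000 nM.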

Compound 3, half-maximal effective concentration: > 11100 nM
Compound 3: only a limit was reported; the forecaster's own chance of this, stated with the estimate: 80%; the middle value sits exactly at the limit.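

No step can be read among compound 1, compound 2 and compound 3, because each result in this assay is only a limit: the limit of > 11100 nM in this assay, at which 3 of the 3 values shown sit.

The compounds shown leave open whether the group on the carbonyl carbon changes the read-out at all.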